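Macrocycle series: chloro to fluoro swap and microsomal stability

The source may hold more compounds than are shown below. What is called first, only, known or untested is meant among the compounds shown, and "the series" means these compounds.

Compound 1 `CC[C@@H]1NC(=O)[C@H](CCCNC(=N)N)NC(=O)[C@](C)(NC(=O)C(C)C)CCCCN(C)C(=O)[C@@H](c2ccc(Cl)cc2)NC1=O` has been run in an ADME assay on microsomes (Mus musculus) for metabolic stability; on this read-out higher numbers stand for a longer-lived compound and lower numbers for a shorter-lived compound. In this assay compound 1 gives > 1 h, which is a limit of the assay rather than a number. Compound 3 `CC[C@@H]1NC(=O)[C@H](CCCNC(=N)NC)NC(=O)[C@](C)(NC(=O)C(C)C)CCNC(=O)[C@@H](c2ccccc2)NC1=O` likewise returns only a limit, > 1 h. Compound 2 `CCC(CC)(NC(=O)C(C)C)C(=O)N[C@@H](CCCNC(=N)N)C(=O)NC1(C(=O)NC(c2ccccc2)c2ccccc2)CCCC1` gives 0.733 h in this assay. Within the data shown here, two of the three values therefore sit at the limit of > 1 h in this assay, at which 2 of the 3 values shown sit, and no step between measured compounds that differ in one place is available. Compound 4 `CC[C@@H]1NC(=O)[C@H](CCCNC(=N)N)NC(=O)[C@](C)(NC(=O)C(C)C)CCCCN(C)C(=O)[C@@H](c2ccc(F)cc2)NC1=O` differs from compound 1 by fluoro in place of chloro on an aromatic carbon. Among the measured compounds shown here, with no measured step to draw on, the expected step that the limit leaves unreadable from compound 1 to compound 4 is none beyond the scatter. Compound 4 is expected to give 1.2 h in this assay, within a range from 0.6 h to 2.5 h, and is likely to be reported again as a limit.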

Compound 4, half-life: > 1 h
Compound 4 ended at the assay's limit (the forecaster's own chance of this, stated with the estimate: 65%); the middle value is on the limit's open side.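

Among these compounds, compound 1 and compound 4 both return only limits in this assay, so no step between them can be read: the limit of > 1 h in this assay, at which 3 of the 4 values shown sit. The compounds shown leave open whether fluoro in place of chloro changes how long the compound lasts.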